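Methylthio for thione in phenoxybenzyl triazoles

The source may report more compounds than this note shows. Statements on the series, on what has been measured and on what is new or still open speak of the compounds shown alone.

Compound 1 `S=c1[nH]nc(Cc2ccccc2Oc2ccccc2)[nH]1` and compound 3 `CSc1nnc(Cc2ccccc2Oc2ccccc2)[nH]1` share a core and differ in one place; compound 2 `S=c1[nH]nc(Cc2ccc(Cl)cc2Oc2ccccc2Cl)[nH]1` carries two chlorine substituents, and the difference between the core of compound 1 and the core of compound 2 is not broken down here. In a functional assay on the whole organism (strain NMRI) with Mus musculus as the target, with a stated time of 60 min, at a dose of 5 mg/kg by the intraperitoneal route (a lower number here means a weaker effect, a higher number a stronger effect of the compound at the dose given), compound 1 gives 126%, compound 2 gives 124% and compound 3 gives 120%. The three numbers all lie within the usual scatter of one another, so no order among them is claimed.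

The change from compound 1 to compound 3 is a group of 7 heavy atoms (3 carbon, 3 nitrogen, 1 sulfur; one five-membered aromatic ring with 3 hetero atoms) in place of a group of 6 heavy atoms (2 carbon, 3 nitrogen, 1 sulfur; one five-membered aromatic ring with 3 hetero atoms), on a saturated chain carbon bound to an aromatic carbon. Its step is a number 6 percentage points lower from compound 1 to compound 3 (within the scatter).

Compound 4 `CSc1nnc(Cc2ccc(Cl)cc2Oc2ccccc2Cl)[nH]1` is not yet measured in this assay. It stands to compound 2 as compound 3 stands to compound 1: the change is a group of 7 heavy atoms (3 carbon, 3 nitrogen, 1 sulfur; one five-membered aromatic ring with 3 hetero atoms) in place of a group of 6 heavy atoms (2 carbon, 3 nitrogen, 1 sulfur; one five-membered aromatic ring with 3 hetero atoms), on a saturated chain carbon bound to an aromatic carbon, the same change at the same place, made here on the dichlorinated core instead of the unsubstituted one.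

The step expected from compound 2 to compound 4 is a number 6 percentage points lower from compound 2 to compound 4 (within the scatter), placed beside the measured one because a number 6 percentage points lower from compound 1 to compound 3 (within the scatter) was within the scatter; no larger effect is anticipated from one example. Within the data shown here, compound 4 is thus estimated at 118% in this assay, with the range 104% to 132% reflecting the ordinary repeat scatter around the single measured step.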

Compound 4, a percentage reported as activity, at one dose (the size of the read-out at that dose, not a potency): 125%
Compound 4: the middle estimate sits 7 percentage points below what was measured; the measured number falls inside the stated range.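

In this assay, the change from thione to methylthio on the dichlorinated core gives a number 1 percentage points higher from compound 2 to compound 4 (within the scatter), and this step does not differ from the one on the unsubstituted core: the same change on two cores in this assay, a number 6 percentage points lower (within the scatter) from compound 1 to compound 3 and a number 1 percentage points higher (within the scatter) from compound 2 to compound 4, 7 percentage points apart, within the scatter of two such steps. Across these two cores, then, the change carries over in the limited sense that neither step can be told from the scatter, and no dependence on the core can be read from the pair. Among these compounds, this does not show that the change is without effect in general or that it would stay silent on other cores, as it rests on only two pairs, and the read-out gives the size of the effect at one dose only, so a stronger or weaker effect at other doses could remain hidden.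

The compounds shown leave open how this assay would respond to a longer chain on the sulfur, such as ethylthio or benzylthio, or to an amine or a carboxylic acid in place of the methylthio group. They also leave open whether a core carrying only one of the two chlorine substituents would behave as the dichlorinated core does, and whether other doses would separate these compounds.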